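Methyl to methoxy on the benzylic aryl ring

The source may report more compounds than this note shows. Statements on the series, on what has been measured and on what is new or still open speak of the compounds shown alone.

Among the compounds with values here, compound 2 `Cc1cccc(CNc2nc(N)nc(-c3ccccc3CO)n2)c1` gives 4.4 in a functional assay on cells for positive allosteric modulation of G-protein coupled receptor 68 (Homo sapiens), read by a luciferase reporter and cAMP accumulation, with a stated time of 30 min, at pH 6.8 and pH 8.3, in the presence of a further agent that is not named here (on this read-out lower numbers stand for lower potency and higher numbers for higher potency (the scale is a negative logarithm)), the lower of the two numbers so far; compound 1 `Nc1nc(NCc2ccccc2Cl)nc(-c2ccccc2CO)n1` gives 5.07, and the change a number 0.67 log units lower from compound 1 to compound 2 (beyond the scatter) swaps the aryl group entirely. Compound 3 `COc1cccc(CNc2nc(N)nc(-c3ccccc3CO)n2)c1` differs from compound 2 by methoxy in place of methyl on an aromatic carbon, on an aromatic carbon of a six-membered aromatic ring of carbon only, meta to a large group. Within the data shown here, no measured step touches this substituent, so the expectation for compound 3 is a step of no change at the digits printed from compound 2 to compound 3 (within the scatter) within the scatter, an estimated 4.4 with a range from 3.9 to 5.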

Compound 3, negative logarithm of the antagonist equilibrium constant: 4.11
Estimate against measurement, compound 3: 0.29 log units above; measured number inside the range.
By their numbers in this assay, from the lowest: compounds 3 and 2 (each within the scatter of the next); then compound 1.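

Methoxy in place of methyl, meta to a large group, leaves the number within the scatter (a number 0.29 log units lower from compound 2 to compound 3 (within the scatter)), so at this position the added hydrogen-bond acceptor and extra heavy atom bring no readable change. The 3-methoxyphenyl group also stays short of the 2-chlorophenyl group (a number 0.96 log units lower from compound 1 to compound 3 (beyond the scatter)), so neither of the two 3-substituted phenyl groups matches compound 1. No measurement at hand bears on the cause of either step.

Still open, from the compounds shown here alone, is whether a different group at this position, such as an amine or a carboxylic acid, would separate from methyl and methoxy. A 3-chlorophenyl group would help show whether the gap to compound 1 follows the chlorine or its place on the ring.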